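Hydroxy on the benzoyl ring of compound 3

The compounds below may be only part of what the source reports. "The series", "measured", "known", "first", "only" and "open" are said of these compounds alone.

Of the compounds shown here, three sharing one core have been tested in a functional assay on A549 cells (Homo sapiens) for cytotoxicity, read by MTT assay, with a stated time of 48 h; a lower number here means a stronger inhibitor, a higher number a weaker inhibitor. Compound 3, `COc1cc(-c2nnc3n2NC(c2ccco2)C(C(=O)c2ccccc2)S3)cc(OC)c1OC`, gives the lowest number of the three, 33400 nM. Compound 1, `COc1cc(-c2nnc3n2NC(c2ccco2)C(C(=O)c2ccc(F)c(F)c2)S3)cc(OC)c1OC`, gives 93700 nM in this assay, and compound 2, `COc1cc(-c2nnc3n2NC(c2ccco2)C(C(=O)c2cccs2)S3)cc(OC)c1OC`, gives 78700 nM. The two steps leading to compound 3 are a 2.8-fold lower number from compound 1 to compound 3 (0.45 log units; beyond the scatter) and a 2.4-fold lower number from compound 2 to compound 3 (0.37 log units; beyond the scatter), while the step between the other two, a 1.2-fold lower number from compound 1 to compound 2 (0.08 log units; within the scatter), is small.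

Compound 4, `COc1cc(-c2nnc3n2NC(c2ccco2)C(C(=O)c2ccc(O)cc2)S3)cc(OC)c1OC`, has not yet been measured in this assay. It differs from compound 3 by hydroxy in place of hydrogen on an aromatic carbon. All three measured steps change the group on the carbonyl carbon, so they bear on this position, yet none of them introduces a hydroxy on an aromatic carbon of a six-membered aromatic ring of carbon only, and the steps seen there were at most modest. A step of similar size, or none beyond the scatter, is therefore expected, with no clear direction. Compound 4 is estimated to give 35000 nM in this assay, within a range of 15000 nM to 80000 nM, which corresponds to an expected step of a 1.0-fold higher number from compound 3 to compound 4 (0.02 log units; within the scatter).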

Compound 4, half-maximal inhibitory concentration: 93400 nM
For compound 4 the middle estimate is 2.7-fold (0.43 log units) below the measured one; the measured number lies above the stated range.
By their numbers in this assay, from the lowest: compound 3; then compounds 2, 4 and 1 (each within the scatter of the next).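

In this assay, for the compounds shown here, the earlier steps all replaced the whole group on the carbonyl carbon, whereas this result shows that a single hydroxy in place of hydrogen on the benzoyl ring is enough to give a 2.8-fold higher number from compound 3 to compound 4 (0.45 log units; beyond the scatter) and so to lose the standing of compound 3 as the lowest of the set. The 4-hydroxyphenyl group puts compound 4 level with the two other groups, with a 1.2-fold higher number from compound 2 to compound 4 (0.07 log units; within the scatter) for the thiophen-2-yl group and a 1.0-fold lower number from compound 1 to compound 4 (0.00 log units; within the scatter) for the 3,4-difluorophenyl group, and neither of these steps lies beyond the scatter. Nothing given here accounts for the rise that the hydroxy brings.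

As far as these compounds go, whether a methoxy, an amine or a carboxylic acid in the same place would bring a step of this size remains open. Also open, from the compounds shown here alone, is whether a hydroxy on another carbon of the ring would do the same, and whether the hydroxy step would hold with a group other than the furan-2-yl group on the shared core.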